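Dimethylphenyl swap on the shared core

The source may report more compounds than this note shows. Statements on the series, on what has been measured and on what is new or still open speak of the compounds shown alone.

Measured so far in a functional assay on HL-60 cells (Homo sapiens) for activation, read by flow cytometry, with a stated time of 4 days; a higher number here means that more compound is needed for the effect, a lower number that less compound is needed:
compound 1, `COc1ccc(-n2cnc3cnc(-c4cccc(NC(C)=O)c4)cc32)cc1OC`: compound 1 reaches only the limit > 30000 nM in this assay.
compound 2, `COc1ccc(-n2cnc3cnc(-c4ccc(F)cc4C)cc32)cn1`: compound 2 gives 70 nM.
compound 3, `Cc1cccc(C)c1-c1cc2c(cn1)ncn2-c1ccc(OC(F)F)cc1`: compound 3 gives 980 nM.

Compound 3 stands at the highest of the two numbers shown, with compound 2 nearest at a clearly lower number, a gap beyond the scatter; compound 1 contributes only a limit, as noted in the limit of > 30000 nM in this assay, at which 1 of the 3 values shown sits.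

Compound 4, `Cc1ccc(-c2cc3c(cn2)ncn3-c2ccc(OC(F)F)cc2)c(C)c1`, is not yet measured. It differs from compound 3 only in 2,4-dimethylphenyl in place of 2,6-dimethylphenyl on an aromatic carbon.

No step between measured compounds is shown, so the size of this change must be estimated from the structural change alone. A modest move to a lower number is expected, a 2.5-fold lower number from compound 3 to compound 4 (0.39 log units; beyond the scatter), with wide uncertainty. Compound 4 is estimated at 400 nM, within 100 nM to 2000 nM.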

Compound 4, half-maximal effective concentration: 180 nM
For compound 4 the middle estimate is 2.2-fold (0.35 log units) above the measured one; the measured number falls inside the stated range.
By their numbers in this assay, from the lowest: compound 2; then compound 4; then compound 3. At a limit, above all of these: compound 1.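

With the same atoms on the shared core, 2,4-dimethylphenyl in place of 2,6-dimethylphenyl on this aromatic carbon gives a 5.4-fold lower number from compound 3 to compound 4 (0.74 log units; beyond the scatter) in this assay. This position therefore responds to the arrangement of the two methyl groups, even with the heavy-atom count and ring type unchanged. No measurement shown gives a cause for this step.

Still open, from the compounds shown here alone, is whether the step holds with another group at the other ring position of the core, as compound 2 differs from compound 4 in more than one place. Also open, going by these compounds, is how this phenyl ring behaves with a single methyl, an amine or a carboxylic acid.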